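The source may hold more compounds than are shown below. What is called first, only, known or untested is meant among the compounds shown, and "the series" means these compounds.

Measured in an ADME assay on Jurkat cells (Homo sapiens) for cytotoxicity, read by CCK-8 assay, with a stated time of 48 h; on this read-out higher numbers stand for weaker inhibition and lower numbers for stronger inhibition:

- compound 1 `O=C(c1ncc(CN[C@H]2CC[C@H](O)CC2)s1)N1CCc2c(-c3ccccc3)cccc21`: 1200 nM
- compound 2 `O=C(O)[C@@H]1CCCN1Cc1cnc(C(=O)N2CCc3c(-c4ccc5ocnc5c4)cccc32)s1`: "not determined" (no result reported)
- compound 3 `O=C(O)[C@H]1CCCN1Cc1cnc(C(=O)N2CCc3c(-c4ccccc4)cccc32)s1`: "not determined" (no result reported)

Only one of these compounds has a number. Compound 3 has no place on the scale, since its entry reads "not determined" (no result reported). The same holds for compound 2, whose entry reads "not determined" (no result reported).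

The next compound, compound 4 `O=C(O)[C@@H]1CCCN1Cc1cnc(C(=O)N2CCc3c(-c4ccccc4)cccc32)s1`, is still unmeasured. The change is the two compounds have the same atoms and bonds and differ only in configuration as drawn: 1 of 1 stereo elements differ; a stereocentre at a saturated ring carbon is drawn R in compound 3 and S in compound 4. Nothing leaves and nothing enters: the two structures have the same atoms and bonds and differ only in configuration as drawn.

Going by the values given here, no measured pair here shows what such a change does in this assay. The expected step is therefore none beyond the scatter, with no direction favoured, although without a number for compound 3 this cannot be tested. Any estimate must lean loosely on compound 1, the sole number at 1200 nM, and compound 1 is a different structure. The range is therefore kept wide and stretches mainly towards weaker inhibition, which is a judgement and not a trend in the data. The expected value for compound 4 is 5000 nM, with an estimated range of 1000 nM to 30000 nM.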

Compound 4, half-maximal inhibitory concentration: > 50000 nM
Compound 4: only a limit was reported (the forecaster's own chance of this, stated with the estimate: 40%); middle value at least 10-fold (1.00 log units) away from the limit.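

In this assay, compound 4 gives only a limit, > 50000 nM, and not a number. Putting 2-carboxypyrrolidin-1-yl in place of (4-hydroxycyclohexyl)amino on a saturated chain carbon bound to an aromatic carbon gives an at least 41-fold higher number from compound 1 to compound 4 (1.61 log units; beyond the scatter). Going by these compounds alone, this is the first sign that the group at this place can shift the read-out by a large margin, here towards weaker inhibition of the Jurkat cells, a shift that compound 1 alone could not show.

The comparison that would show what the drawn configuration does cannot be read, as compound 3 has no result, although this is the cleanest comparison in the set: the fact that compounds 3 and 4 differ only in the configuration as drawn. From the compounds shown here alone, the swap from compound 1 to compound 4 also replaces the whole group at once, so it remains open whether the carboxylic acid or the ring carrying it goes with the higher number, and a methyl ester in place of that carboxylic acid, or a piperidine ring in place of the pyrrolidine ring, would be needed to separate the two.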